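Working notes: three limits and a trifluoromethyl analogue

The source may hold more compounds than are shown below. What is called first, only, known or untested is meant among the compounds shown, and "the series" means these compounds.

Measured so far:
compound 1 `O=S(=O)(Nc1ccc(-c2nc3ccccc3o2)cc1)c1cccs1` — in an assay on isolated protein for inhibition of malate dehydrogenase, mitochondrial (Sus scrofa), with stated times of 45 min and 30 min (on this read-out lower numbers stand for stronger inhibition and higher numbers for weaker inhibition), compound 1 gives > 63000 nM, a limit of the assay
compound 2 `O=S(=O)(Nc1ccc(-c2nc3ccccc3o2)cc1)c1ccc(Cl)s1` — compound 2 gives > 63000 nM, again a limit
compound 3 `CCc1ccc(S(=O)(=O)Nc2ccc(-c3nc4ccccc4o3)cc2)cc1` — compound 3 gives > 63000 nM, also a limit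

None of the three values is a number; all three sit at the limit of > 63000 nM in this assay, at which 3 of the 3 values shown sit. Compound 3 therefore stands at the same limit as compound 1 and compound 2, and nothing separates it from them on the numbers shown. The steps between the measured compounds are accordingly unreadable: a step that the two limits leave unreadable from compound 1 to compound 2, a step that the two limits leave unreadable from compound 1 to compound 3 and a step that the two limits leave unreadable from compound 2 to compound 3 cannot be sized, so they give no direction for any further change.

Compound 4 `O=S(=O)(Nc1ccc(-c2nc3ccccc3o2)cc1)c1ccc(C(F)(F)F)cc1` differs from compound 3 in one place: trifluoromethyl in place of ethyl on an aromatic carbon. For the measured compounds named here, no measured step bears readably on this exchange, since every step in the set is hidden by the limit. The working expectation is therefore no readable step from compound 3 to compound 4 in this assay, with the estimated step that the limit leaves unreadable from compound 3 to compound 4 carrying little weight. Compound 4 is estimated at 80000 nM, within a range from 25000 nM to 250000 nM, and most likely the assay will again return only a limit.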

Compound 4, half-maximal inhibitory concentration: > 63000 nM
Compound 4: no number, only a limit; the forecaster's own chance of this, stated with the estimate: 75%; the middle value does not contradict the limit.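

For the compounds shown here, compound 4 gives > 63000 nM in this assay, a limit and not a number, so no step from compound 3 to compound 4 can be read. Compound 1, compound 2, compound 3 and compound 4 all share one limit: the limit of > 63000 nM in this assay, at which 4 of the 4 values shown sit.

The compounds shown leave open whether any group on the sulfonyl sulfur gives a measurable value in this assay.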